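Urea series: demethylating the aryl ether of compound 2

The compounds below may be only part of what the source reports. "The series", "measured", "known", "first", "only" and "open" are said of these compounds alone.

For the measured compounds named here, compound 1 `O=C(Nc1cccc(-n2cc(-c3ccncc3)c(-c3ccc(Cl)c(O)c3)n2)c1)Nc1cccc(C(F)(F)F)c1` and compound 2 `COc1cc(-c2nn(-c3cccc(NC(=O)Nc4cc(C(F)(F)F)cc(C(F)(F)F)c4)c3)cc2-c2ccncc2)ccc1Cl` share one core but differ in two places at once, so no single measured step joins them. In a functional assay on T47D cells (Homo sapiens) for inhibition, read by sulforhodamine B assay, with a stated time of 48 h (on this read-out lower numbers stand for stronger inhibition of growth and higher numbers for weaker inhibition of growth), compound 1 reaches only the limit of the measurement, > 32500 nM. In this assay compound 2 likewise stands at a limit, > 50000 nM. Both entries are therefore limits rather than numbers, as recorded in the limit of > 32500 nM in this assay, at which 1 of the 2 values shown sits, and (the limit of > 50000 nM in this assay, at which 1 of the 2 values shown sits). Compound 3 `O=C(Nc1cccc(-n2cc(-c3ccncc3)c(-c3ccc(Cl)c(O)c3)n2)c1)Nc1cc(C(F)(F)F)cc(C(F)(F)F)c1` carries the urea end of compound 2 together with the hydroxy of compound 1. From compound 2 to compound 3 the change is hydrogen in place of methyl on an oxygen on an aromatic ring, methoxy to hydroxy, 4-chloro-3-methoxyphenyl to 4-chloro-3-hydroxyphenyl. Both measured neighbours of compound 3 sit at limits, so no direction can be read from them. The expected step of a number no higher from compound 2 to compound 3 (the limit leaves the size open) is none beyond the scatter. Compound 3 is expected to give in this assay about 50000 nM, within 20000 nM to 120000 nM, most probably reported again only as a limit.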

Compound 3, concentration for total growth inhibition: 14000 nM
Estimate against measurement, compound 3: 3.6-fold (0.55 log units) above; the whole stated range lies above it.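

Working notes on the urea series. In this assay, for the compounds shown here, compound 3 gives 14000 nM and is the only one of the three compounds that yields a number rather than a limit, so this pair of changes is the first to bring the series into measurable range. At the oxygen on the aromatic ring, methoxy to hydroxy gives an at least 3.5-fold lower number from compound 2 to compound 3 (0.55 log units; beyond the scatter) with the urea end held constant, while trifluoromethyl in place of hydrogen on an aromatic carbon gives an at least 2.3-fold lower number from compound 1 to compound 3 (0.36 log units; beyond the scatter) with the hydroxy held constant, so both places bear on growth inhibition here. Each step is only a lower bound because it starts from a limit: (the limit of > 32500 nM in this assay, at which 1 of the 3 values shown sits) and (the limit of > 50000 nM in this assay, at which 1 of the 3 values shown sits).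

As far as these compounds go, the true size of either step stays unknown, and the two cannot be ranked against each other. Also open, from the compounds shown here alone, is whether the gain depends on the hydroxy itself, since an amine, a carboxylic acid or an ethoxy in that place, or a fluorine in place of a trifluoromethyl on the urea end, would test how narrow this requirement is.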